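The source may hold more compounds than are shown below. What is called first, only, known or untested is meant among the compounds shown, and "the series" means these compounds.

Compound 2 `COc1cc(-c2nn(-c3cccc(NC(=O)Nc4ccc(Cl)c(Cl)c4)c3)cc2-c2ccncc2)ccc1Cl` and compound 1 `O=C(Nc1cccc(-n2cc(-c3ccncc3)c(-c3ccc(Cl)c(O)c3)n2)c1)Nc1cccc(C(F)(F)F)c1` share the same core but differ in more than one place, so no single change separates them. In a functional assay on OVCAR-3 cells (Homo sapiens) for inhibition, read by sulforhodamine B assay, with a stated time of 48 h (on this read-out higher numbers stand for weaker inhibition of growth and lower numbers for stronger inhibition of growth), compound 2 gives 697 nM, and compound 1 gives 1060 nM; the two numbers sit within the scatter of each other. Compound 3 `O=C(Nc1cccc(-n2cc(-c3ccncc3)c(-c3ccc(Cl)c(O)c3)n2)c1)Nc1ccc(Cl)c(Cl)c1` is compound 2 with one change, (hydrogen in place of methyl on an oxygen on an aromatic ring), a methoxy turned into a hydroxy. Among the measured compounds shown here, with no measured single-place step to lean on, no shift beyond the scatter is expected here. Compound 3 is therefore estimated at 800 nM, between 300 nM and 2500 nM, an expected step of a 1.1-fold higher number from compound 2 to compound 3 (0.06 log units; within the scatter).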

Compound 3, concentration for 50% growth inhibition: 1050 nM
Estimate against measurement, compound 3: 1.3-fold (0.12 log units) below, and the stated range covers the measured number.
By their numbers in this assay, from the lowest: compounds 2, 3 and 1 (each within the scatter of the next).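

Methoxy and hydroxy on this aromatic ring can now be compared directly in this assay (a 1.5-fold higher number from compound 2 to compound 3 (0.18 log units; within the scatter)), and the step lies within the scatter, so this position tolerates either group in this pair. The same holds on the amide-type nitrogen, where 3,4-dichlorophenyl takes the place of 3-(trifluoromethyl)phenyl (a 1.0-fold lower number from compound 1 to compound 3 (0.00 log units; within the scatter)). No supporting measurement is available to explain either result.
The compounds shown leave open whether an ethoxy group or a longer chain on this oxygen would shift growth inhibition beyond the scatter. An amine in place of the hydroxy also remains an open question.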